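The source may report more compounds than this note shows. Statements on the series, on what has been measured and on what is new or still open speak of the compounds shown alone.

Compound 3 `COc1ncnc2c1c(-c1ccoc1)cn2[C@@H]1O[C@H](CO)[C@@H](O)[C@H]1O` carries a furan-3-yl group on the shared core. In a functional assay on CEM-DNR-bulk cells (Homo sapiens), read by MTT assay, with a stated time of 72 h (on this read-out lower numbers stand for stronger inhibition and higher numbers for weaker inhibition), compound 3 gives only a limit of the assay, > 20000 nM, so no number is known for it (the limit of > 20000 nM in this assay, at which 1 of the 3 values shown sits). Compound 1 `COc1ncnc2c1c(-c1ccsc1)cn2[C@@H]1O[C@H](CO)[C@@H](O)[C@H]1O` gives 7640 nM in this assay, and compound 2 `COc1ncnc2c1c(-c1cc3ccccc3o1)cn2[C@@H]1O[C@H](CO)[C@@H](O)[C@H]1O` gives 10800 nM. The step of an at least 2.6-fold higher number from compound 1 to compound 3 (0.41 log units; beyond the scatter) lies beyond the scatter, whereas an at least 1.8-fold higher number from compound 2 to compound 3 (0.26 log units; that floor lies within the scatter) and a 1.4-fold higher number from compound 1 to compound 2 (0.15 log units; within the scatter) do not. Compound 4 `CSc1ncnc2c1c(-c1ccoc1)cn2[C@@H]1O[C@H](CO)[C@@H](O)[C@H]1O` differs from compound 3 by methylsulfanyl in place of methoxy on an aromatic carbon. Among the compounds with values here, none of the measured steps concerns this change, all of them touching the five-membered ring instead, so no direction can be drawn from them. Compound 4 is therefore expected to sit near where compound 3 sits, with a good chance of another limit, at an estimated 25000 nM (range 8000 nM to 80000 nM). The expected step is a step that the limit leaves unreadable from compound 3 to compound 4.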

Compound 4, half-maximal inhibitory concentration: > 20000 nM
Compound 4 gave a limit, no number; the forecaster's own chance of this, stated with the estimate: 60%; the middle value is on the limit's open side.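

Compound 3 and compound 4 both stop at a limit of the assay, so no step between them can be read in this assay: the limit of > 20000 nM in this assay, at which 2 of the 4 values shown sit.

The compounds shown leave open whether methylsulfanyl in place of methoxy changes the read-out at all.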